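Removing the (morpholin-4-yl)carbonyl group from compound 2

This account rests on a few compounds, and the source may have more. Where it says the series, first, only, none or still open, it means among the compounds named here.

- Compound 1 `COc1ncc(-c2ccc3nc(NC(=O)NCC(=O)N4CCCC4)nn3c2)cc1NS(=O)(=O)c1ccc(F)cc1` gives 2190 nM
- Compound 2 `COc1ncc(-c2ccc3nc(NC(=O)NCC(=O)N4CCOCC4)nn3c2)cc1NS(=O)(=O)c1ccc(F)cc1` gives 2570 nM

Going by the values given here, in a functional assay on A549 cells (Homo sapiens) for cytotoxicity, read by MTT assay, with a stated time of 72 h (on this read-out lower numbers stand for stronger inhibition and higher numbers for weaker inhibition), compound 2 gives 2570 nM and cannot be told apart from compound 1, so it stands level with the only other measured compound. Compound 3 `CNC(=O)Nc1nc2ccc(-c3cnc(OC)c(NS(=O)(=O)c4ccc(F)cc4)c3)cn2n1` differs from compound 2 as follows: hydrogen in place of (morpholin-4-yl)carbonyl on a saturated chain carbon bound to an amide-type nitrogen. This leaves a methylcarbamoyl group where the longer chain stood. Among the compounds with values here, only one measured step bears on this change: a 1.2-fold higher number from compound 1 to compound 2 (0.07 log units; within the scatter). That step exchanged one ring for another and stayed within the scatter, but the carbonyl group remained in place. It therefore says little about removing the whole group, and the data give no firm direction. A moderate step towards a lower number is tentatively expected, namely a 2.1-fold lower number from compound 2 to compound 3 (0.33 log units; beyond the scatter). Compound 3 is estimated at 1200 nM, with an expected range from 300 nM to 5000 nM.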

Compound 3, half-maximal inhibitory concentration: 230 nM
Compound 3: the middle estimate sits 5.2-fold (0.72 log units) above what was measured; the whole stated range lies above it.
By their numbers in this assay, from the lowest: compound 3; then compounds 1 and 2 (each within the scatter of the next).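

Removing the carbonyl-and-ring group from the chain lowers the number sharply in this assay, both for the morpholine compound (an 11-fold lower number from compound 2 to compound 3 (1.05 log units; beyond the scatter)) and for the pyrrolidine compound (a 9.5-fold lower number from compound 1 to compound 3 (0.98 log units; beyond the scatter)). The earlier exchange of one ring for the other stayed within the scatter and so gave no sign of this. Among these compounds, the large change comes from having a methylcarbamoyl group in place of either longer chain, not from which of the rings the chain carries, and nothing at hand explains why.

The compounds shown leave open how far the chain can grow before the number rises again, for example with an ethyl or propyl group in place of methyl. They also leave open whether a small amine or a carboxylic acid at the end of the chain would give a low number too.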